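Swapping a Difluorophenyl Urea for a Thiazolyl Urea

The source may report more compounds than this note shows. Statements on the series, on what has been measured and on what is new or still open speak of the compounds shown alone.

Compound 1 `Nc1n[nH]c2cccc(-c3cccc(NC(=O)Nc4ccc(F)c(F)c4)c3)c12`: 5880 nM
Compound 2 `Nc1n[nH]c2cccc(-c3cccc(NC(=O)Nc4cc(C(F)(F)F)cc(C(F)(F)F)c4)c3)c12`: 3540 nM

Of the compounds shown here, two built on one shared core have been tested in a functional assay on SMMC-7721 cells (Homo sapiens) for inhibition, read by MTT assay, with a stated time of 48 h; a lower number here means a stronger inhibitor, a higher number a weaker inhibitor. Compound 1 gives 5880 nM, and compound 2 gives 3540 nM. Compound 1 has the highest of the two numbers, yet its gap to compound 2 lies within the scatter, so the two read alike.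

From the compounds shown here alone, compound 3 `Nc1n[nH]c2cccc(-c3cccc(NC(=O)Nc4nccs4)c3)c12` is untested. It differs from compound 1 in one place: 1,3-thiazol-2-yl in place of 3,4-difluorophenyl on an amide-type nitrogen. Among the compounds with values here, no measured pair shows what this change does, so only a modest step in this assay is expected, in either direction. Compound 3 is estimated at 4500 nM, between 1500 nM and 15000 nM, meaning an expected step of a 1.3-fold lower number from compound 1 to compound 3 (0.12 log units; within the scatter).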

Compound 3, half-maximal inhibitory concentration: 550 nM
Beside the measured number, compound 3's estimate is 8.2-fold (0.91 log units) above it; measured number outside the range, below it.
By their numbers in this assay, from the lowest: compound 3; then compounds 2 and 1 (each within the scatter of the next).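

Putting 1,3-thiazol-2-yl in place of 3,4-difluorophenyl on the amide-type nitrogen gives an 11-fold lower number from compound 1 to compound 3 (1.03 log units; beyond the scatter) in this assay. This position is therefore sensitive to the group it carries, and here a five-membered aromatic ring with 2 hetero atoms outperforms the difluorinated six-membered ring. Nothing available explains this gain.

From the compounds shown here alone, it remains open whether the gain depends on the thiazole's sulfur, its ring nitrogen or simply the loss of the fluorines. Plain phenyl, 1,3-oxazol-2-yl and pyridin-2-yl at this place would help separate these possibilities.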